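This account rests on a few compounds, and the source may have more. Where it says the series, first, only, none or still open, it means among the compounds named here.

Compound 1 `CC(C)[C@H](NC(=O)COc1cccc2ccccc12)C(=O)N[C@@H](CC(=O)O)C(=O)CSC1=NCCS1` was examined in a functional assay on Jurkat cells (Homo sapiens) for inhibition; on this read-out lower numbers stand for stronger inhibition and higher numbers for weaker inhibition. In this assay compound 1 gives > 200000 nM, which is a limit of the assay and not a number. Two companions share the same core. Compound 2 `CC(C)[C@H](NC(=O)COc1cccc2ccccc12)C(=O)N[C@@H](CC(=O)O)C(=O)CSc1nncn1C` gives > 200000 nM in this assay, again only a limit. Compound 3 `CC(C)[C@H](NC(=O)COc1cccc2ccccc12)C(=O)N[C@@H](CC(=O)O)C(=O)CSc1nc2ccccc2s1` gives > 200000 nM in this assay, likewise a limit. The steps among them, a step that the two limits leave unreadable from compound 1 to compound 2, a step that the two limits leave unreadable from compound 1 to compound 3 and a step that the two limits leave unreadable from compound 2 to compound 3, cannot be read, as all three values sit at the limit of > 200000 nM in this assay, at which 3 of the 3 values shown sit. Compound 4 `CC(C)[C@H](NC(=O)COc1cccc2ccccc12)C(=O)N[C@@H](CC(=O)O)C(=O)COc1nccc(C(F)(F)F)n1` is not yet measured. It differs from compound 1 by a group of 11 heavy atoms (5 carbon, 2 nitrogen, 1 oxygen, 3 fluorine; one six-membered aromatic ring with 2 hetero atoms) in place of a group of 6 heavy atoms (3 carbon, 1 nitrogen, 2 sulfur; one five-membered non-aromatic ring with 2 hetero atoms), on a saturated chain carbon bound to a carbonyl carbon. Among the compounds with values here, the three measured steps each exchange a ring on the sulfur and none of them yields a readable size; the change to compound 4 is of another kind, and no measured step resembles it. No direction can be drawn from the numbers, so the expectation rests on the three limits alone. The chemist expects compound 4 to remain at the limit as well, with a number no higher from compound 1 to compound 4 (the limit leaves the size open) as the estimated step. The estimated value for compound 4 is 200000 nM, in a range from 20000 nM to 2000000 nM, and the most likely outcome is expected to be that only a limit is again reported.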

Compound 4, half-maximal inhibitory concentration: > 200000 nM
Compound 4: only a limit was reported (the forecaster's own chance of this, stated with the estimate: 80%); the middle value sits exactly at the limit.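

Compound 4 also gives only a limit of the assay and not a number, so the steps to it from compound 1, compound 2 and compound 3 cannot be read: the limit of > 200000 nM in this assay, at which 4 of the 4 values shown sit.

The compounds shown leave open what number any of the four would reach in this assay, and whether any group at this place on the shared core changes it.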